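Methyl for Trifluoromethyl on the Aryl Ring of Compound 3

The source may report more compounds than this note shows. Statements on the series, on what has been measured and on what is new or still open speak of the compounds shown alone.

Measured compounds:
compound 1 `CCC(C(=O)N1CCN(c2cccc(OC)c2)CC1)N1C(=O)CCC1=O`: 0%
compound 2 `CCC(C(=O)N1CCN(c2ccccc2F)CC1)N1C(=O)CCC1=O`: 50%
compound 3 `CCC(C(=O)N1CCN(c2cccc(C(F)(F)F)c2)CC1)N1C(=O)CCC1=O`: 100%

In a functional assay on the whole organism (strain Swiss) with Mus musculus as the target, in the maximal electroshock model, with a stated time of 1 h, at a dose of 300 mg/kg by the intraperitoneal route (a higher number here means a stronger effect of the compound at the dose given, a lower number a weaker effect), compound 1 gives 0% and compound 2 gives 50%. Compound 3 stands highest of the three measured in this assay with 100%; the nearest is compound 2 and the furthest is compound 1.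

Compound 4 `CCC(C(=O)N1CCN(c2cccc(C)c2)CC1)N1C(=O)CCC1=O` is not yet measured. It differs from compound 3 in one place: methyl in place of trifluoromethyl on an aromatic carbon.

Among the measured compounds shown here, the only measured step touching this position of the ring is a number 100 percentage points higher from compound 1 to compound 3 (beyond the scatter), which exchanged methoxy for trifluoromethyl and was large. The step of a number 50 percentage points higher from compound 1 to compound 2 (beyond the scatter) changed a different position together with the group and is less direct. For the measured compounds named here, no measured pair shows methyl at this position, so the size of the step in this assay is estimated from the one large step alone. Compound 4 is expected to lose part of the effect of compound 3, estimated at a number 50 percentage points lower from compound 3 to compound 4 (beyond the scatter), because a number 100 percentage points higher from compound 1 to compound 3 (beyond the scatter) shows this position to matter strongly. Compound 4 is therefore estimated at 50%, with a range of 0% to 100%.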

Compound 4, a percentage reported as activity, at one dose (the size of the read-out at that dose, not a potency): 75%
Compound 4: middle estimate off by 25 percentage points, on the low side; the range from low to high includes it.
By their numbers in this assay, from the lowest: compound 1; then compound 2; then compound 4; then compound 3.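

Compound 4 shows that trifluoromethyl is not required on this aromatic carbon for an effect in this assay: replacing it with methyl gives a step of modest size (a number 25 percentage points lower from compound 3 to compound 4 (beyond the scatter)). Methoxy and methyl, by contrast, are far apart at this position (a number 75 percentage points higher from compound 1 to compound 4 (beyond the scatter)), so the large loss seen with compound 1 is not shared by every group other than trifluoromethyl. Compound 4 also stands above the 2-fluorophenyl compound (a number 25 percentage points higher from compound 2 to compound 4 (beyond the scatter)), and no measured evidence accounts for any of these differences.

Going by these compounds, whether a chloro group, an ethyl group, a hydroxyl or an amine on this carbon would keep the effect remains open. The same holds for the other ring positions, as methyl and trifluoromethyl are compared at only one place and one dose.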